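A few compounds are considered here, and "the series" means these few. Any claim that something is new, unique, unknown or untested is made for them only; others in the source may bear on it.

Of the compounds shown here, three share one amide-linked core and have been tested in a functional assay on the whole organism (strain albino) with Rattus norvegicus as the target, read by paw edema, with stated times of 1 h and 4 h, at a dose of 50 mg/kg by the oral route; on this read-out higher numbers stand for a stronger effect at the one dose given and lower numbers for a weaker effect. Compound 1 `COc1ccc(/C=C/C(=O)c2ccc(NC(=O)c3cc(Cl)ccc3OC)cc2)cc1` gives 93.1%. Compound 2 `COc1ccc(Cl)cc1C(=O)Nc1ccc(C(=O)/C=C/c2ccccc2[N+](=O)[O-])cc1` gives 85.9%. Compound 3 `COc1ccc(C2CC(c3ccc(NC(=O)c4cc(Cl)ccc4OC)cc3)=NN2C)cc1` gives 93.2%, the largest of the three numbers, though its gap to compound 1 and its gap to compound 2 both lie within the scatter, so none of the three can be set apart from the others.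

Compound 4 `COc1ccc(Cl)cc1C(=O)Nc1ccc(C2=NN(C)C(c3ccc([N+](=O)[O-])cc3)C2)cc1` is not yet measured. It differs from compound 3 in one place: nitro in place of methoxy on an aromatic carbon. Within the data shown here, one measured step bears on this change. Going a number 7.2 percentage points lower from compound 1 to compound 2 (within the scatter), a nitro-bearing ring took the place of a 4-methoxyphenyl group on the chain of the open-chain pair, and the number stayed within the scatter. Among the measured compounds shown here, that step is the only guide, and it swaps a 2-nitrophenyl rather than a 4-nitrophenyl, on a different part of the molecule. On that basis no step beyond the scatter is expected in this assay, and the expected move is a number 5.2 percentage points lower from compound 3 to compound 4 (within the scatter). Compound 4 is therefore estimated at 88%, within a range from 76% to 96%.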

Compound 4, a percentage reported as activity, at one dose (the size of the read-out at that dose, not a potency): 97.4%
Compound 4: the middle estimate sits 9.4 percentage points below what was measured, outside the stated range (above it).
By their numbers in this assay, from the lowest: compounds 2, 1, 3 and 4 (each within the scatter of the next, the first and the last beyond it).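

In this assay, putting nitro in place of methoxy on this aromatic carbon gives a number 4.2 percentage points higher from compound 3 to compound 4 (within the scatter). The earlier nitro comparison involved a 2-nitrophenyl group on the open-chain pair, whereas this one tests the same spot on the framework of compound 3, changing 4-methoxyphenyl to 4-nitrophenyl with the other parts held constant. At this position, the two groups cannot be told apart at the one dose given, and no measurement is available to explain that outcome.

On these data alone, it remains open whether a different group at this position, such as an amine or a carboxylic acid, would produce a step beyond the scatter. A single-dose read-out also leaves open whether compound 3 and compound 4 would separate at lower doses.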